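A few compounds are considered here, and "the series" means these few. Any claim that something is new, unique, unknown or untested is made for them only; others in the source may bear on it.

Measured in a functional assay on SK-OV-3 cells (Homo sapiens) for cytotoxicity, read by MTT assay, with a stated time of 24 h; on this read-out higher numbers stand for weaker inhibition and lower numbers for stronger inhibition:
- compound 1 `C#CCn1c(=O)c(C=O)cc2ccccc21`: > 100000 nM
- compound 2 `C=CCn1c(=O)c(/C=C/C(=O)/C=C(O)/C=C/c2ccc(O)c(OC)c2)cc2ccccc21`: 26000 nM
- compound 3 `C#CCn1c(=O)c(/C=C/C(=O)/C=C(O)/C=C/c2ccc(O)c(OC)c2)cc2ccccc21`: 19000 nM

The value of compound 1 is a limit of the assay and not a number. Compound 3 gives the lowest of the two true numbers, but it stands within the scatter of compound 2. Compound 4 `C#CCn1c(=O)c(/C=C/C(=O)/C=C(O)/C=C/c2ccc(O)c(OC)c2)cc2cc(OC)ccc21` differs from compound 3 by methoxy in place of hydrogen on an aromatic carbon. Going by the values given here, the only measured step, a 1.4-fold lower number from compound 2 to compound 3 (0.14 log units; within the scatter), is ethynyl in place of vinyl at another place, so it says little about this change. No step beyond the scatter is therefore expected in this assay, and the expected step is a 1.1-fold lower number from compound 3 to compound 4 (0.05 log units; within the scatter). Compound 4 is estimated at 17000 nM, with an expected range of 7000 nM to 40000 nM.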

Compound 4, half-maximal inhibitory concentration: 14000 nM
Beside the measured number, compound 4's estimate is 1.2-fold (0.08 log units) above it, and the stated range covers the measured number.
By their numbers in this assay, from the lowest: compounds 4, 3 and 2 (each within the scatter of the next). At a limit, above all of these: compound 1.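

Methoxy in place of hydrogen on this aromatic carbon, meta to a fused ring and para to a fused ring, gives in this assay a 1.4-fold lower number from compound 3 to compound 4 (0.13 log units; within the scatter). The position therefore takes methoxy without a step beyond the scatter, a reading that the change from vinyl to ethynyl elsewhere on the molecule could not give. Nothing measured here accounts for the size of this step.

On these data alone, whether an amine, a carboxylic acid or a longer chain at this position would give a step beyond the scatter stays open. So does whether methoxy here would give the same step alongside the vinyl group of compound 2.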